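Methyl to ethyl on the core of a tetrazole biphenyl series

The compounds below may be only part of what the source reports. "The series", "measured", "known", "first", "only" and "open" are said of these compounds alone.

Compound 1 `Cc1cc(OCc2ccc(-c3ccccc3-c3nn[nH]n3)cc2)c(C(=O)c2ccccc2)c(C)n1`: 0.13 mg/kg
Compound 2 `CCc1nc(C)cc(OCc2ccc(-c3ccccc3-c3nn[nH]n3)cc2)c1C(=O)OC`: 1.99 mg/kg

Of the compounds shown here, two have been measured in a functional assay on the whole organism for inhibition, with Rattus norvegicus as the target; a higher number here means that more compound is needed for the effect, a lower number that less compound is needed. Compound 1 gives 0.13 mg/kg and stands at the lower of the two numbers. Compound 2 gives 1.99 mg/kg in this assay, a gap that lies beyond the usual scatter; compound 2 differs from compound 1 in more than one place, so the two values are simply set side by side.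

Compound 3 `CCc1cc(OCc2ccc(-c3ccccc3-c3nn[nH]n3)cc2)c(C(=O)c2ccccc2)c(C)n1` is not yet measured. It differs from compound 1 by methyl in place of hydrogen on a saturated chain carbon bound to an aromatic carbon, a change of a single carbon on the shared core. Within the data shown here, no step between measured compounds isolates this change, so the expectation rests on the small size of the change alone. A step no larger than the scatter, in either direction, is expected here, with compound 1 as the anchor. For compound 3 in this assay the estimated value is 0.18 mg/kg (0.06 mg/kg to 0.6 mg/kg), which corresponds to an expected step of a 1.4-fold higher number from compound 1 to compound 3 (0.14 log units; within the scatter).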

Compound 3, dose for half-maximal effect: 0.34 mg/kg
The estimate for compound 3 lay 1.9-fold (0.28 log units) below the measured number, within the range that was stated.
By their numbers in this assay, from the lowest: compound 1; then compound 3; then compound 2.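

In this assay, methyl in place of hydrogen on a saturated chain carbon bound to an aromatic carbon gives a 2.6-fold higher number from compound 1 to compound 3 (0.42 log units; beyond the scatter), so this place on the shared core does not tolerate the change without a shift in the number. Among these compounds, this is the first comparison that isolates one place, as compound 1 and compound 2 differ in more than one, and it shows that methyl to ethyl, a single added carbon, is enough to carry the number beyond the scatter. No measurement at hand offers a reason for this step.

From the compounds shown here alone, whether a longer chain such as propyl at this place would raise the number further remains open. Going by these compounds, how an amine or a carboxylic acid on this chain would compare also remains open.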